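Swapping the aryl on the core: compound 1 to compound 3

The source may report more compounds than this note shows. Statements on the series, on what has been measured and on what is new or still open speak of the compounds shown alone.

For the measured compounds named here, compound 1 `Cc1ccc(S(=O)(=O)c2cnc3cc(F)ccc3c2-c2ccc(F)cc2)cc1C` is one of two compounds measured in an ADME assay on microsomes from liver (Homo sapiens) for metabolic stability, tested at 2.5 uM (on this read-out higher numbers stand for fast clearance and lower numbers for slow clearance), where compound 1 gives 9.25 mL/min, the higher of the two numbers. The other, compound 2 `O=S(=O)(c1cc(Cl)cc(Cl)c1)c1cnc2cc(F)ccc2c1-c1ccc(F)cc1`, gives 0.18 mL/min in this assay, and the step of a 51-fold lower number from compound 1 to compound 2 (1.71 log units; beyond the scatter) is the only one available. Compound 3 `Cc1ccc(S(=O)(=O)c2cnc3cc(F)ccc3c2-c2cccc(Cl)c2)cc1C` has not been measured. It differs from compound 1 by 3-chlorophenyl in place of 4-fluorophenyl on an aromatic carbon, on an aromatic carbon of the core opposite the ring nitrogen. The measured step from compound 1 to compound 2 concerns a group on a sulfonyl sulfur, a different place, so it offers no direct guide to the change at hand. Going by the values given here, with no step at this position to draw on, compound 3 is expected to stay close to compound 1, with a step of a 1.0-fold lower number from compound 1 to compound 3 (0.01 log units; within the scatter) that is expected to lie within the scatter. The estimate for compound 3 in this assay is 9 mL/min, with a range from 3 mL/min to 27 mL/min.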

Compound 3, intrinsic clearance in a liver preparation (reported as CLH), per the amount of preparation that the assay uses: 4.01 mL/min
Compound 3: the middle estimate sits 2.2-fold (0.35 log units) above what was measured; the range from low to high includes it.
By their numbers in this assay, from the lowest: compound 2; then compound 3; then compound 1.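

The position on the core opposite the ring nitrogen is not silent in this assay: a 2.3-fold lower number from compound 1 to compound 3 (0.36 log units; beyond the scatter), a modest step beyond the scatter, and the first one read at this place. It is smaller than a 51-fold lower number from compound 1 to compound 2 (1.71 log units; beyond the scatter), which lies on the sulfonyl sulfur, and the 3-chlorophenyl for 4-fluorophenyl change alters both the halogen and where it sits on the ring, so the step cannot be assigned to either alone. Nothing at hand offers a reason for this step.

As far as these compounds go, it remains open how 3-fluorophenyl or 4-chlorophenyl would read at this place, which would pull those two changes apart, and how an aryl carrying an amine or a carboxylic acid would behave. Also open, from the compounds shown here alone, is whether 3-chlorophenyl and 3,5-dichlorophenyl together would add up.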